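The compounds below may be only part of what the source reports. "The series", "measured", "known", "first", "only" and "open" are said of these compounds alone.

Compound 1 `CN(CCCNC(=O)Nc1ccc(C(C)(C)C)cc1)C[C@H]1C[C@@H](c2ccc3c(N)ncnn23)[C@H](O)[C@@H]1O`: 18.4 L/kg
Compound 2 `CC(C)NC[C@@H]1C[C@H](c2ccc3c(N)ncnn23)[C@@H](O)[C@H]1O`: 4.43 L/kg

In an ADME assay on the whole organism (Mus musculus, strain BALB/c) for pharmacokinetics, read by LC-MS, with a stated time of 600 min, at a dose of 20 mg/kg by the intravenous route (a lower number here means that more of the compound stays in the plasma, a higher number that more of the compound sits outside the plasma), compound 2 stands lower of the two at 4.43 L/kg, and its gap to compound 1 lies beyond the scatter. Compound 3 `CC(C)NC[C@H]1C[C@@H](c2ccc3c(N)ncnn23)[C@H](O)[C@@H]1O` is not yet measured. Its relation to compound 2 is the two compounds have the same atoms and bonds and differ only in configuration as drawn: 4 of 4 stereo elements differ (all stereocentres are inverted: mirror images); a stereocentre at a saturated ring carbon is drawn S in compound 2 and R in compound 3; a stereocentre at a saturated ring carbon is drawn R in compound 2 and S in compound 3; a stereocentre at a saturated ring carbon is drawn R in compound 2 and S in compound 3; a stereocentre at a saturated ring carbon is drawn S in compound 2 and R in compound 3. Among the compounds with values here, no measured pair shows what such an inversion does, so the expectation starts from compound 2 at 4.43 L/kg and is for no step beyond the scatter, in either direction. The expected size is a 1.0-fold higher number from compound 2 to compound 3 (0.01 log units; within the scatter). In this assay compound 3 is estimated at 4.5 L/kg, with an expected range from 2.2 L/kg to 9 L/kg.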

Compound 3, volume of distribution: 3.88 L/kg
Estimate against measurement, compound 3: 1.2-fold (0.06 log units) above, and the stated range covers the measured number.
By their numbers in this assay, from the lowest: compounds 3 and 2 (each within the scatter of the next); then compound 1.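

Inverting all stereocentres at once gives a 1.1-fold lower number from compound 2 to compound 3 (0.06 log units; within the scatter) in this assay and is the first such pair in the series. Within the data shown here, for this pair, configuration as drawn leaves the two numbers within the scatter of each other, which the earlier compounds could not show. The comparison isolates configuration alone: the fact that compounds 2 and 3 differ only in the configuration as drawn.

Still open, from the compounds shown here alone, is whether inverting only some of the stereocentres would leave the numbers as close. Also open, going by these compounds, is whether the same full inversion would do so in a compound carrying a carboxylic acid on the amine side chain.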